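The source may hold more compounds than are shown below. What is called first, only, known or untested is meant among the compounds shown, and "the series" means these compounds.

Compound 2 `O=C1C(Nc2ccc(F)cc2)=CC(=O)c2ncncc21` is one of two measured members of this series; in a functional assay on HCT-15 cells (Homo sapiens) for cytotoxicity, read by MTT assay, with a stated time of 72 h (a higher number here means a weaker inhibitor, a lower number a stronger inhibitor), compound 2 gives 0.02 ug/mL. Its nearest neighbour, compound 1 `CCOc1ccc(NC2=CC(=O)c3ncncc3C2=O)cc1`, gives 0.02 ug/mL in this assay, and the step from compound 1 to compound 2 was no change at the digits printed from compound 1 to compound 2 (within the scatter), with fluoro in place of ethoxy on an aromatic carbon. Compound 2 therefore stands level with compound 1 at the digits shown.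

Compound 3 `O=C1C(Nc2ccccc2)=CC(=O)c2ncncc21` has not yet been measured in this assay. It differs from compound 2 by hydrogen in place of fluoro on an aromatic carbon. Going by the values given here, the only measured step that bears on this position is the one from compound 1 to compound 2, which was no change at the digits printed from compound 1 to compound 2 (within the scatter) even though that exchange was the larger one. On that basis the step from compound 2 to compound 3 is expected to be no change at the digits printed from compound 2 to compound 3 (within the scatter), nothing beyond the scatter. Compound 3 is accordingly estimated at 0.02 ug/mL, with a range from 0.008 ug/mL to 0.05 ug/mL.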

Compound 3, half-maximal inhibitory concentration: 0.01 ug/mL
For compound 3 the middle estimate is 2.0-fold (0.30 log units) above the measured one, within the range that was stated.
By their numbers in this assay, from the lowest: compounds 3, 1 and 2 (each within the scatter of the next).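

With hydrogen on this carbon, the position para to a large group carries no substituent at all, yet this assay reads a 2.0-fold lower number from compound 2 to compound 3 (0.30 log units; within the scatter) and the exchange of ethoxy for hydrogen on the same carbon reads a 2.0-fold lower number from compound 1 to compound 3 (0.30 log units; within the scatter) in the same assay. The earlier pair showed only that fluoro could stand in for ethoxy, whereas these steps show that neither group is needed here for the reading on these cells, with all three compounds within the scatter of one another. Nothing available here bears on why this position accepts these exchanges.

Going by these compounds, whether an amine, a carboxylic acid or a longer alkoxy chain on this carbon would leave the reading where it is remains open. So does the effect of any change to the shared core.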